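The source may report more compounds than this note shows. Statements on the series, on what has been measured and on what is new or still open speak of the compounds shown alone.

Values in a functional assay on SF-268 cells (Homo sapiens) for inhibition, read by sulforhodamine B assay, with a stated time of 48 h; a lower number here means a stronger inhibitor of growth, a higher number a weaker inhibitor of growth:
Compound 1 `O=C(Cc1csc2nc(-c3ccc(Br)cc3)cn12)N/N=C/c1ccccc1`: < 100000 nM, a limit.
Compound 2 `O=C(Cc1csc2nc(-c3ccc(Br)cc3)cn12)N/N=C/c1ccc(O)cc1`: < 100000 nM, a limit.
Compound 3 `COc1cccc(OC)c1/C=N/NC(=O)Cc1csc2nc(-c3ccc(Br)cc3)cn12`: < 100000 nM, a limit.

Compound 1 gives no number, and the whole set rests on (the limit of < 100000 nM in this assay, at which 3 of the 3 values shown sit). Compound 4 `O=C(Cc1csc2nc(-c3ccc(Br)cc3)cn12)N/N=C/c1ccc(Cl)cc1Cl` has not yet been measured. It differs from compound 1 in one place, on a carbon with a double bond to nitrogen, where 2,4-dichlorophenyl stands in place of phenyl: 2,4-dichlorophenyl in place of phenyl on a carbon with a double bond to nitrogen.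

Going by the values given here, three measured steps bear on this change. The closest is a step that the two limits leave unreadable from compound 1 to compound 3, which also replaces the phenyl on that carbon. The other two are a step that the two limits leave unreadable from compound 1 to compound 2 and a step that the two limits leave unreadable from compound 2 to compound 3. None of them has a readable size or direction, so none can be carried over to compound 4. Among the compounds with values here, no step of known size is therefore expected in this assay, and no direction can be favoured.

The expectation rests on compound 1 and its limit of < 100000 nM. It is quite possible that compound 4 will also be reported only as a limit. Within the data shown here, the expected change is a step that the limit leaves unreadable from compound 1 to compound 4, a rough estimate with no measured step behind its size. For compound 4 the estimated value is 40000 nM, with an expected range from 8000 nM to 100000 nM.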

Compound 4, concentration for 50% growth inhibition: < 100000 nM
Compound 4 gave a limit, no number (the forecaster's own chance of this, stated with the estimate: 70%); the middle value lies beyond the limit too.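

In this assay compound 4 gives < 100000 nM as a limit and not a number. Going by these compounds alone, no step between compound 4 and compound 1, compound 2 or compound 3 can be read, in size or in direction: the limit of < 100000 nM in this assay, at which 4 of the 4 values shown sit. The compounds shown leave open how strongly any of the four inhibits growth, and whether changing the group on the carbon with a double bond to nitrogen alters that at all.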